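The source may report more compounds than this note shows. Statements on the series, on what has been measured and on what is new or still open speak of the compounds shown alone.

Of the compounds shown here, three that share one core have been measured in an ADME assay on MT2 cells (Homo sapiens) for inhibition; on this read-out higher numbers stand for lower toxicity in this test and lower numbers for higher toxicity in this test. In this assay compound 1 `CCc1cc(F)c(Cc2cnc(Nc3ccc(C#N)c(Cl)c3)o2)c(F)c1` gives 10000 nM, compound 2 `N#Cc1ccc(Nc2ncc(Cc3c(F)cc(CC4CC4)cc3F)o2)cc1Cl` gives 29000 nM, and compound 3 `CCC(C)c1cc(F)c(Cc2cnc(Nc3ccc(C#N)c(Cl)c3)o2)c(F)c1` gives 40000 nM. Compound 3 thus stands highest of the three numbers, although its gap to compound 2 lies within the scatter, while its gap to compound 1 lies beyond it. The step to the unmeasured compound 4 `COCc1cc(F)c(Cc2cnc(Nc3ccc(C#N)c(Cl)c3)o2)c(F)c1` is methoxymethyl in place of sec-butyl on an aromatic carbon. Two measured steps change the group on this same aromatic carbon: a 4.0-fold higher number from compound 1 to compound 3 (0.60 log units; beyond the scatter) and a 2.9-fold higher number from compound 1 to compound 2 (0.46 log units; beyond the scatter), whereas there is a 1.4-fold higher number from compound 2 to compound 3 (0.14 log units; within the scatter). In both steps beyond the scatter a group with more carbon atoms went with a higher number. Within the data shown here, compound 4 carries a group with fewer heavy atoms at this position, and the oxygen it brings has no measured precedent here. Because of a 4.0-fold higher number from compound 1 to compound 3 (0.60 log units; beyond the scatter) a modest downward step is expected for compound 4, namely a 2.7-fold lower number from compound 3 to compound 4 (0.43 log units; beyond the scatter). For compound 4 the estimate in this assay is 15000 nM, with a range from 5000 nM to 45000 nM.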

Compound 4, half-maximal cytotoxic concentration: 15000 nM
Estimate against measurement, compound 4: no gap at the digits printed, within the range that was stated.
By their numbers in this assay, from the lowest: compounds 1, 4, 2 and 3 (each within the scatter of the next, the first and the last beyond it).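

In this assay, among these compounds, replacing sec-butyl with methoxymethyl, the first group at this position to carry an oxygen and a hydrogen-bond acceptor, gives a 2.7-fold lower number from compound 3 to compound 4 (0.43 log units; beyond the scatter). The closest test of the oxygen itself is methoxy in place of the end methyl of the chain, and this gives a 1.5-fold higher number from compound 1 to compound 4 (0.18 log units; within the scatter), so the swap leaves no readable change. Methoxy in place of cyclopropyl on the same chain carbon gives a 1.9-fold lower number from compound 2 to compound 4 (0.29 log units; within the scatter), so compound 4 cannot be separated from compound 2 either, and only sec-butyl stands apart from methoxymethyl.

No measurement shown explains these steps. As far as these compounds go, it remains open how an amine, a carboxylic acid or a longer ether chain at this position would read out, and whether an oxygen placed elsewhere in the chain would behave like this one.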